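Pyrrolidine to piperidine at the end of the chain

The compounds below may be only part of what the source reports. "The series", "measured", "known", "first", "only" and "open" are said of these compounds alone.

Within the data shown here, compound 3 `COc1cc2c(Nc3nc4ccc(C(=O)Nc5c(C)cccc5Cl)cc4s3)ncnc2cc1OCCCN1CCCC1` stands at the higher end of the two numbers measured so far: in a functional assay on NCI-H661 cells (Homo sapiens) for cytotoxicity, read by WST assay, with a stated time of 72 h (on this read-out lower numbers stand for stronger inhibition and higher numbers for weaker inhibition), compound 3 gives 45500 nM. Its nearest relative, compound 1 `COc1cc2c(Nc3nc4ccc(C(=O)Nc5c(C)cccc5Cl)cc4s3)ncnc2cc1OCCCN1CCCCC1C`, gives 5300 nM in this assay. The unmeasured compound 4 `COc1cc2c(Nc3nc4ccc(C(=O)Nc5c(C)cccc5Cl)cc4s3)ncnc2cc1OCCCN1CCCCC1` differs from compound 3 only at the amine end of the chain: piperidin-1-yl in place of pyrrolidin-1-yl on a saturated chain carbon, three bonds along the chain from an oxygen on an aromatic ring. The third measured member, compound 2 `COc1cc2c(Nc3nc4ccc(C(=O)Nc5c(C)cccc5C)cc4s3)ncnc2cc1OCCCN1CCCCC1`, carries the same piperidin-1-yl as compound 4 but a different anilide; in this assay compound 2 gives > 100000 nM, which is the limit of > 100000 nM in this assay, at which 1 of the 3 values shown sits, and not a number. Among the measured compounds shown here, the one measured step that bears on the change is an 8.6-fold higher number from compound 1 to compound 3 (0.93 log units; beyond the scatter). Since compound 4 restores a six-membered ring, it is expected to recover part of that loss and to fall between compound 3 and compound 1. For compound 4 the estimate in this assay is 15000 nM, within 5000 nM to 50000 nM, which corresponds to an expected step of a 3.0-fold lower number from compound 3 to compound 4 (0.48 log units; beyond the scatter).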

Compound 4, half-maximal inhibitory concentration: 13800 nM
Compound 4: the middle estimate sits 1.1-fold (0.04 log units) above what was measured; measured number inside the range.
By their numbers in this assay, from the lowest: compound 1; then compound 4; then compound 3. At a limit, above all of these: compound 2.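

In this assay the earlier step, an 8.6-fold higher number from compound 1 to compound 3 (0.93 log units; beyond the scatter), changed ring size and ring methyl together, and it now separates into two single changes: ring size alone gives a 3.3-fold lower number from compound 3 to compound 4 (0.52 log units; beyond the scatter), and hydrogen in place of methyl on a saturated ring carbon gives a 2.6-fold higher number from compound 1 to compound 4 (0.42 log units; beyond the scatter). Both steps lie beyond the scatter, so the enlarged ring and the methyl each count in this series of compounds. On the anilide, chloro in place of methyl on an aromatic carbon gives an at least 7.2-fold lower number from compound 2 to compound 4 (0.86 log units; beyond the scatter), a step that starts from a limit and not from a number: the limit of > 100000 nM in this assay, at which 1 of the 4 values shown sits.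

The compounds shown leave open whether a morpholine at the end of the chain would fit this order. They also leave open whether a methyl on the pyrrolidine ring, or a longer chain, would change these numbers in the same way.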